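Working notes: replacing the 2-chloro-4-fluorophenyl group of compound 2

A few compounds are considered here, and "the series" means these few. Any claim that something is new, unique, unknown or untested is made for them only; others in the source may bear on it.

In a functional assay on PC-3 cells (Homo sapiens) for antiproliferative activity, read by MTT assay, with a stated time of 72 h (a higher number here means a weaker inhibitor, a lower number a stronger inhibitor), compound 1 (`O=C(N/N=C/c1ccc(Br)cc1)Nc1ccc(Oc2ccnc3[nH]ccc23)c(F)c1`) gives 920 nM and compound 2 (`O=C(N/N=C/c1ccc(F)cc1Cl)Nc1ccc(Oc2ccnc3[nH]ccc23)c(F)c1`) gives 3 nM. Among the compounds with values here, compound 2 therefore holds the lower of the two numbers measured so far.

Compound 3 (`O=C(N/N=C/c1ccc(O)cc1)Nc1ccc(Oc2ccnc3[nH]ccc23)c(F)c1`) has not yet been measured in this assay. It differs from compound 2 as follows: 4-hydroxyphenyl in place of 2-chloro-4-fluorophenyl on a carbon with a double bond to nitrogen. In words, 4-hydroxyphenyl stands in place of 2-chloro-4-fluorophenyl on a carbon with a double bond to nitrogen.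

Within the data shown here, only one measured step bears on this change: a 310-fold lower number from compound 1 to compound 2 (2.49 log units; beyond the scatter). It involves the same place and is large, so replacing this group can move the number far beyond the scatter. Like compound 1 at 920 nM, compound 3 lacks the 2-chloro-4-fluorophenyl group. Among the measured compounds shown here, no measured compound carries 4-hydroxyphenyl, so the size of the change remains uncertain.

For the measured compounds named here, a large rise in the number is expected, somewhat smaller than the one measured step. The expected step is a 50-fold higher number from compound 2 to compound 3 (1.70 log units; beyond the scatter). The estimate for compound 3 is 150 nM, with an expected range of 15 nM to 1500 nM.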

Compound 3, half-maximal inhibitory concentration: 2780 nM
Compound 3: the middle estimate sits 19-fold (1.27 log units) below what was measured; the whole stated range lies below it.
By their numbers in this assay, from the lowest: compound 2; then compound 1; then compound 3.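

Notes on the result: in this assay, the change from 2-chloro-4-fluorophenyl to 4-hydroxyphenyl gives a larger step (a 930-fold higher number from compound 2 to compound 3 (2.97 log units; beyond the scatter)) than the one already measured for 4-bromophenyl and 2-chloro-4-fluorophenyl (a 310-fold lower number from compound 1 to compound 2 (2.49 log units; beyond the scatter)). The step between the two groups lacking the 2-chloro-4-fluorophenyl group, hydroxy in place of bromo on an aromatic carbon, is only modest though still beyond the scatter (a 3.0-fold higher number from compound 1 to compound 3 (0.48 log units; beyond the scatter)), so among these three compounds the low number belongs to compound 2 alone, and neither of the other two comes close to it. Nothing available accounts for the size of these steps or for the order of the three compounds.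

The compounds shown do not separate the chloro from the fluoro contribution, since 2-chlorophenyl and 4-fluorophenyl analogues are absent, and it remains unclear whether either group alone would retain the low number of compound 2. Going by these compounds, it is also open how a 4-methoxyphenyl or 4-aminophenyl group at this place would compare with the 4-hydroxyphenyl of compound 3 and the 4-bromophenyl of compound 1.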